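This account rests on a few compounds, and the source may have more. Where it says the series, first, only, none or still open, it means among the compounds named here.

Three compounds built on one shared core were tested in an assay on CHO cells for displacement of a labelled ligand from adenosine receptor A1 (Homo sapiens), with a stated time of 60 min, tested at 10 uM; a lower number here means less inhibition, a higher number more inhibition at the concentration tested (going by the name of the read-out). Compound 1 `CCOC(=O)C1=C(C)N(C)C(=O)NC1c1ccco1` gives 17% in this assay. Compound 2 `CC1=C(C(=O)OC(C)C)C(c2ccco2)NC(=O)N1C` differs from compound 1 by methyl in place of hydrogen on a saturated chain carbon bound to an oxygen next to a carbonyl group and a saturated chain carbon, and in this assay compound 2 gives 28%. That change brought a number 11 percentage points higher from compound 1 to compound 2 (beyond the scatter). Compound 3 `CCOC(=O)C1=C(C)N(C)C(=O)NC1c1ccoc1` differs from compound 1 in its core by furan-3-yl in place of furan-2-yl on a saturated ring carbon; in this assay compound 3 gives 17%, so the change of core gave no change at the digits printed from compound 1 to compound 3 (within the scatter). Compound 1 and compound 3 thus sit level with each other, while compound 2 stands higher than compound 1 and, by the values alone, higher than compound 3 as well.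

Compound 4 `CC1=C(C(=O)OC(C)C)C(c2ccoc2)NC(=O)N1C` has not yet been measured in this assay. Within the data shown here, it differs from compound 3 by methyl in place of hydrogen on a saturated chain carbon bound to an oxygen next to a carbonyl group and a saturated chain carbon, the same change as the one from compound 1 to compound 2, at a place described in the same words. Its core differs from that of compound 1 and compound 2 in the way already described for compound 3. Among the measured compounds shown here, only one earlier example of this change is at hand, so the expectation rests on that single step a number 11 percentage points higher from compound 1 to compound 2 (beyond the scatter) together with the fact that the change of core produced no change within the scatter. On that basis the step is expected to come out as a number 11 percentage points higher from compound 3 to compound 4 (beyond the scatter). Compound 4 is therefore estimated at 28% in this assay, with a range expected from 15% to 42%.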

Compound 4, a percentage reported as inhibition, at one concentration (the size of the read-out at that concentration, not a potency): 23%
For compound 4 the middle estimate is 5 percentage points above the measured one, within the range that was stated.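

Replacing ethoxycarbonyl with isopropoxycarbonyl on the core of compound 3 gave a number 6 percentage points higher from compound 3 to compound 4 (within the scatter) in this assay, and this step does not differ from the earlier one on the core of compound 1: the same change on two cores in this assay, a number 11 percentage points higher (beyond the scatter) from compound 1 to compound 2 and a number 6 percentage points higher (within the scatter) from compound 3 to compound 4, 5 percentage points apart, within the scatter of two such steps

Read on the isopropoxycarbonyl pair, the change from furan-2-yl to furan-3-yl gave a number 5 percentage points lower from compound 2 to compound 4 (within the scatter), which likewise does not differ from its earlier counterpart: the same change on two cores in this assay, no change at the digits printed (within the scatter) from compound 1 to compound 3 and a number 5 percentage points lower (within the scatter) from compound 2 to compound 4, 5 percentage points apart, within the scatter of two such steps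

Across these four compounds, then, neither change shows any sign of depending on the core it is made on, but this does not establish that the methyl change raises the number on both cores, as only the step on the core of compound 1 lies beyond the scatter, and two pairs read at a single concentration give neither a potency nor a rule for other cores.

The compounds shown leave open how a longer chain on the ester oxygen would read in this assay. They also leave open whether a carboxylic acid or an amine in place of the ester group would follow the same steps.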